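Lengthening the ester chain from compound 2 to compound 3

A few compounds are considered here, and "the series" means these few. Any claim that something is new, unique, unknown or untested is made for them only; others in the source may bear on it.

In a functional assay on THP-1 cells (Homo sapiens) for inhibition, with a stated time of 48 h, tested at 50 uM (a lower number here means less inhibition of growth, a higher number more inhibition of growth at the concentration tested), compound 1 (`C=C[C@@](C)(/C=C/c1ccc(OC(=O)CCCC)cc1)CCC=C(C)C`) gives 15% at the concentration tested, while compound 2 (`C=C[C@@](C)(/C=C/c1ccc(OC(=O)CCCCCCCCC)cc1)CCC=C(C)C`) gives 52% and so holds the higher of the two numbers. The two differ in one place, on the saturated chain attached to the carbonyl carbon.

Compound 3 (`C=C[C@@](C)(/C=C/c1ccc(OC(=O)CCCCCCCCCCCCCCC)cc1)CCC=C(C)C`) extends that same chain further, and the change from compound 2 is hexyl in place of hydrogen on a saturated chain carbon, nine bonds along the chain from a carbonyl carbon with the rest of the structure untouched. Going by the values given here, the only measured step that bears on this change is a number 37 percentage points higher from compound 1 to compound 2 (beyond the scatter) and it is large, with pentyl entering in place of hydrogen on the same chain. It is also a single step, and two compounds cannot show whether a rise continues with a further hexyl, levels off or reverses. The expected result in this assay is therefore a number 3 percentage points higher from compound 2 to compound 3 (within the scatter) with no step beyond the scatter anticipated, and a move in either direction remains possible. For compound 3 the estimated value is 55% with 25% to 80% as the expected range.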

Compound 3, percent growth inhibition at one concentration: 62%
Beside the measured number, compound 3's estimate is 7 percentage points below it, within the range that was stated.
By their numbers in this assay, from the lowest: compound 1; then compounds 2 and 3 (each within the scatter of the next).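

In this assay the hexyl placed nine bonds along the chain from the carbonyl carbon gives a number 10 percentage points higher from compound 2 to compound 3 (within the scatter) and so, unlike the pentyl that separated compound 2 from compound 1, this further extension does not set its two compounds apart. Read over the full length of the change, undecyl in place of hydrogen four bonds along the chain from the carbonyl carbon gives a number 47 percentage points higher from compound 1 to compound 3 (beyond the scatter) and thus compound 2 and compound 3 both stand clear of compound 1, with no reversal beyond the scatter across the three chain lengths shown. Nothing available explains why the large step appears between compound 1 and compound 2 but no step beyond the scatter appears between compound 2 and compound 3.

The compounds shown leave open whether a longer chain than that of compound 3 would keep the number at this level or lower it, and whether a branched chain, or an amine or a carboxylic acid at the far end of the chain, would be tolerated. They also leave open how an amide in place of the ester would compare at the same chain length.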